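The source may hold more compounds than are shown below. What is called first, only, known or untested is meant among the compounds shown, and "the series" means these compounds.

Measured in a functional assay on PC-3 cells (Homo sapiens) for antiproliferative activity, read by MTT assay, with a stated time of 72 h; a higher number here means a weaker inhibitor, a lower number a stronger inhibitor:
- compound 1 `O=C(N/N=C/c1ccc(F)cc1)Nc1ccc(Oc2ccnc3[nH]ccc23)c(F)c1` gives 2330 nM
- compound 2 `O=C(N/N=C/c1ccccc1)Nc1ccc(Oc2ccnc3[nH]ccc23)cc1` gives 10200 nM
- compound 3 `O=C(N/N=C/c1ccc(Br)cc1)Nc1ccc(Oc2ccnc3[nH]ccc23)cc1` is reported as "not active" (no number reported)

Going by the values given here, compound 3 has no number to stand on: the only result for compound 3 is "not active" (no number reported), so it cannot be placed on the scale beside compound 1 and compound 2. Compound 4 `O=C(N/N=C/c1ccc(F)cc1)Nc1ccc(Oc2ccnc3[nH]ccc23)cc1` has not yet been measured. The change is fluoro in place of bromo on an aromatic carbon. Among the compounds with values here, no measured pair shows this change alone, so its size cannot be read from the data. The expected direction in this assay is toward a countable value, with a large step from no reported number. Compound 1, which also carries the 4-fluorophenyl, gives 2330 nM, and compound 2 gives 10200 nM. The estimated value for compound 4 is 6000 nM, with an expected range of 1800 nM to 20000 nM.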

Compound 4, half-maximal inhibitory concentration: 7490 nM
The estimate for compound 4 lay 1.2-fold (0.10 log units) below the measured number; the range from low to high includes it.
By their numbers in this assay, from the lowest: compound 1; then compounds 4 and 2 (each within the scatter of the next).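

In this assay fluoro in place of hydrogen on the aromatic ring gives a 1.4-fold lower number from compound 2 to compound 4 (0.13 log units; within the scatter) and so leaves no clear mark at this position. The second fluoro of compound 1, on a different aromatic carbon, gives a readable difference, with its loss giving a 3.2-fold higher number from compound 1 to compound 4 (0.51 log units; beyond the scatter) as the result. The size of the bromo to fluoro change itself cannot be read, as compound 3 has no number.

No measurement here explains these results. From the compounds shown here alone, whether a methoxy group or an amine para to the large group would match fluoro remains open.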